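The source may hold more compounds than are shown below. What is called first, only, known or untested is meant among the compounds shown, and "the series" means these compounds.

Measured compounds:
- compound 1, `Nc1ccccc1NC(=O)CCCCCCc1nc(-c2ccc(C(F)(F)F)cc2)no1`, in an assay on isolated protein for inhibition of histone deacetylase 8 (Homo sapiens), read by fluorescence, with a stated time of 10 min (on this read-out lower numbers stand for stronger inhibition and higher numbers for weaker inhibition), compound 1 gives > 10000 nM, a limit of the assay rather than a number.
- compound 2, `COc1ccc(-c2noc(CCCCCCC(=O)C(F)(F)F)n2)cc1`, in this assay compound 2 gives 1860 nM.

Within the data shown here, compound 2 is the only compound with a number in this assay; the other value shown is a limit, as stated in the limit of > 10000 nM in this assay, at which 1 of the 2 values shown sits. Among the measured compounds shown here, there is no pair of measured compounds that differ in only one place, so no measured step is available to guide the next change.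

Compound 3, `O=C(CCCCCCc1nc(-c2ccc(C(F)(F)F)cc2)no1)C(F)(F)F`, has not yet been measured in this assay. Compared with compound 2 it carries trifluoromethyl in place of methoxy on an aromatic carbon. Compound 1 also carries a trifluoromethyl group, but it differs from compound 2 in more than one place, so its value, a limit, says nothing direct about this single exchange.

For the measured compounds named here, with no measured step to lean on, the expectation is that the exchange of methoxy for trifluoromethyl moves the value little, not beyond the usual scatter in either direction. Compound 3 is therefore estimated at 2000 nM, within 600 nM to 7000 nM, meaning an expected step of a 1.1-fold higher number from compound 2 to compound 3 (0.03 log units; within the scatter).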

Compound 3, half-maximal inhibitory concentration: 1030 nM
The estimate for compound 3 lay 1.9-fold (0.29 log units) above the measured number; measured number inside the range.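

In this assay, the position on the aromatic carbon para to a large group now has its first single exchange: trifluoromethyl in place of methoxy gives a 1.8-fold lower number from compound 2 to compound 3 (0.26 log units; within the scatter), so this exchange does not separate the two compounds, even though the two groups differ in size and in hydrogen-bond acceptors. The other end of the molecule gives a clearer signal: with the rest of the structure shared, trifluoromethyl in place of (2-aminophenyl)amino on a carbonyl carbon gives an at least 9.7-fold lower number from compound 1 to compound 3 (0.98 log units; beyond the scatter), so in these three compounds the group on the carbonyl carbon counts for more than the exchange on the aromatic ring. The true size of that step cannot be read, and it stands only as a lower bound because compound 1 sits at a limit of the assay rather than at a number: the limit of > 10000 nM in this assay, at which 1 of the 3 values shown sits.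

From the compounds shown here alone, it remains open whether any other group at the aromatic position, such as a nitrile or a single chlorine atom, would move the number beyond the scatter. Also open, going by these compounds, is how a hydroxyamino group on the carbonyl carbon, or a longer chain, would compare with compound 3.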